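Swapping the aryl group on the amine nitrogen

This account rests on a few compounds, and the source may have more. Where it says the series, first, only, none or still open, it means among the compounds named here.

Measured so far in a functional assay on HeLa cells (Homo sapiens) for inhibition, read by sulforhodamine B assay; a lower number here means a stronger inhibitor, a higher number a weaker inhibitor:
Compound 1 (`CCc1ccc(NC2=CC(=O)c3c(nc4n3[C@H]3OC[C@@H](O)[C@H]3OC4)C2=O)cc1`) gives 6510 nM
Compound 2 (`Cc1ccc(NC2=CC(=O)c3c(nc4n3[C@H]3OC[C@@H](O)[C@H]3OC4)C2=O)cc1C`) gives 4320 nM

Compound 2, at 4320 nM, lies within the scatter of compound 1, so the two cannot be ranked. Compound 3 (`O=C1C(Nc2ccc(C(F)(F)F)cc2)=CC(=O)c2c1nc1n2[C@H]2OC[C@@H](O)[C@H]2OC1`) keeps the shared core but carries 4-(trifluoromethyl)phenyl in place of 3,4-dimethylphenyl on an amine nitrogen. Among the measured compounds shown here, only one measured step bears on this change: a 1.5-fold lower number from compound 1 to compound 2 (0.18 log units; within the scatter), also a swap of the aryl group on that nitrogen. For the measured compounds named here, no compound with a trifluoromethyl group has been measured, so the direction remains open. A step no larger than the scatter is therefore expected in this assay. The estimated change is a 1.0-fold higher number from compound 2 to compound 3 (0.02 log units; within the scatter). Compound 3 is expected near 4500 nM, within an estimated range of 1800 nM to 11000 nM.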

Compound 3, half-maximal inhibitory concentration: 8920 nM
The estimate for compound 3 lay 2.0-fold (0.30 log units) below the measured number, and the stated range covers the measured number.
By their numbers in this assay, from the lowest: compounds 2, 1 and 3 (each within the scatter of the next, the first and the last beyond it).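

In this assay, the result shows that changing the aryl group on the amine nitrogen can move the number beyond the scatter: with 4-(trifluoromethyl)phenyl in place of 3,4-dimethylphenyl there is a 2.1-fold higher number from compound 2 to compound 3 (0.31 log units; beyond the scatter), although this step is modest. Trifluoromethyl in place of ethyl on an aromatic carbon gives a 1.4-fold higher number from compound 1 to compound 3 (0.14 log units; within the scatter), which lies within the scatter, so compound 1 and compound 3 cannot be ranked. No available data explain these differences.

The compounds shown carry only alkyl or trifluoromethyl groups on the phenyl ring, so it remains open how this position would respond to a phenyl ring bearing an amine or a carboxylic acid. From the compounds shown here alone, it is also open whether a cyclohexyl group on the nitrogen, in place of an aryl group, would keep the activity seen in this assay.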